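A few compounds are considered here, and "the series" means these few. Any claim that something is new, unique, unknown or untested is made for them only; others in the source may bear on it.

Working notes on a functional assay on MCF7 cells (Homo sapiens) for cytotoxicity, read by MTT assay, with a stated time of 48 h; a higher number here means a weaker inhibitor, a lower number a stronger inhibitor. Compound 1 `O=C1/C(=C\c2ccccc2)S/C(=N/c2ccccc2)N1Cc1ccncc1` gives 26400 nM, compound 2 `Cc1ccc(/C=C2/S/C(=N/c3ccccc3)N(Cc3ccncc3)C2=O)cc1` gives 36900 nM and compound 3 `O=C1/C(=C\c2ccc([N+](=O)[O-])cc2)S/C(=N/c2ccccc2)N1Cc1ccncc1` gives 13000 nM. Compound 3 stands lowest of the three, beyond the scatter against each of the others.

Compound 4 `CN(C)c1ccc(/C=C2/S/C(=N/c3ccccc3)N(Cc3ccncc3)C2=O)cc1` has dimethylamino in place of nitro on an aromatic carbon, para to a large group (dimethylamino in place of nitro on an aromatic carbon).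

Within the data shown here, three measured steps bear on this change. Nitro in place of hydrogen gave a 2.0-fold lower number from compound 1 to compound 3 (0.31 log units; beyond the scatter), and nitro in place of methyl gave a 2.8-fold lower number from compound 2 to compound 3 (0.45 log units; beyond the scatter). Both are modest. Methyl in place of hydrogen gave a 1.4-fold higher number from compound 1 to compound 2 (0.15 log units; within the scatter), which stays within the scatter. Among the measured compounds shown here, no measured compound carries dimethylamino, so its own contribution is unknown.

With nitro gone, compound 4 is expected to sit nearer compound 1 at 26400 nM and compound 2 at 36900 nM than compound 3. The expected step is modest, toward a higher number: a 2.3-fold higher number from compound 3 to compound 4 (0.36 log units; beyond the scatter). In this assay the estimate for compound 4 is 30000 nM, with an expected range of 13000 nM to 70000 nM.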

Compound 4, half-maximal inhibitory concentration: 76300 nM
For compound 4 the middle estimate is 2.5-fold (0.41 log units) below the measured one; the whole stated range lies below it.
By their numbers in this assay, from the lowest: compound 3; then compounds 1 and 2 (each within the scatter of the next); then compound 4.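

In this assay, this position, para to a large group, now shows that a substituent can raise the number beyond the scatter relative to hydrogen: dimethylamino gives a 2.9-fold higher number from compound 1 to compound 4 (0.46 log units; beyond the scatter) and a 2.1-fold higher number from compound 2 to compound 4 (0.32 log units; beyond the scatter). Nitro and dimethylamino thus fall on opposite sides of hydrogen, and their exchange gives a 5.9-fold higher number from compound 3 to compound 4 (0.77 log units; beyond the scatter), the widest step in the series, leaving compound 4 as the weakest of the four compounds. No measurement here accounts for this opposite direction.

From the compounds shown here alone, whether a methoxy group, a chlorine atom or a primary amine at this position would fit within this span remains open. Going by these compounds, all four compounds vary at this one position, so whether the same order holds with changes elsewhere on the shared core also remains open.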